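Replacing the 3-methylazetidin-1-yl group of compound 2

The compounds below may be only part of what the source reports. "The series", "measured", "known", "first", "only" and "open" are said of these compounds alone.

In an ADME assay (liver) for metabolic stability, with Liver microsome (Homo sapiens) as the target, using microsomes (a lower number here means slower removal, a higher number faster removal of the compound), compound 1 `Cc1cnc(NC(=O)c2cc(Oc3ccc(C(=O)N(C)C)nc3)c3cc(C)oc3c2)cn1` gives 11.6 mL/min/kg. Compound 2 `Cc1cc2c(Oc3cnc(C(=O)N4CC(C)C4)cn3)cc(C(=O)Nc3cnccn3)cc2o1` returns no exact number, only a limit of the assay, < 9.6 mL/min/kg. Compound 3 `Cc1cc2c(Oc3cnc(C(=O)N4CC5(COC5)C4)cn3)cc(C(=O)Nc3cnccn3)cc2o1` keeps the core of compound 2 and changes the group on a carbonyl carbon: a group of 7 heavy atoms (5 carbon, 1 nitrogen, 1 oxygen; 2 four-membered non-aromatic rings with 1 hetero atom each) in place of a group of 5 heavy atoms (4 carbon, 1 nitrogen; one four-membered non-aromatic ring with 1 hetero atom), on a carbonyl carbon. Among the compounds with values here, no measured step between two compounds bears on this change, and no shift beyond the scatter is expected in this assay. The expected move is a step that the limit leaves unreadable from compound 2 to compound 3. For compound 3 the estimate is 9.5 mL/min/kg, with an expected range of 6 mL/min/kg to 15 mL/min/kg.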

Compound 3, clearance in the Liver microsome assay: 12.9 mL/min/kg
Beside the measured number, compound 3's estimate is 1.4-fold (0.13 log units) below it; the range from low to high includes it.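

In the Liver microsome assay compound 3 gives 12.9 mL/min/kg. In the Liver microsome assay compound 2 returns only a limit of the assay, < 9.6 mL/min/kg. In the Liver microsome assay the group with two four-membered rings on the carbonyl carbon gives an at least 1.3-fold higher number from compound 2 to compound 3 (0.12 log units; that floor lies within the scatter), so only a floor of this step can be read. The true size of the step stays unread because compound 2 carries a limit and not a number: the limit of < 9.6 mL/min/kg in the Liver microsome assay, at which 1 of the 3 values shown sits. In a physicochemical assay for solubility, measured as kinetic solubility (a lower number here means a less soluble compound, a higher number a more soluble compound), compound 2 gives 49000 nM and compound 3 gives 43000 nM. In the physicochemical assay the same change gives a 1.1-fold lower number from compound 2 to compound 3 (0.06 log units; within the scatter), so both compounds read alike there.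

As far as these compounds go, how a morpholin-4-yl group or a longer chain on this carbonyl carbon would read in either the Liver microsome assay or the physicochemical assay stays open.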